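A few compounds are considered here, and "the series" means these few. Any claim that something is new, unique, unknown or untested is made for them only; others in the source may bear on it.

Compound 1 `CCCCCC(CCO)n1cnc2c(N(C)C)ncnc21`: > 50000 nM
Compound 2 `CCCCCCCCCCC(CCO)n1cnc2c(OC)ncnc21`: 8260 nM

Both compounds were tested in a functional assay on SW480 cells (Homo sapiens) for antiproliferative activity, read by MTT assay, with a stated time of 48 h; on this read-out lower numbers stand for stronger inhibition and higher numbers for weaker inhibition. For compound 1, the result of > 50000 nM is a limit of the assay and not a number. Within the data shown here, compound 2, at 8260 nM, gives the only true number so far, so there is no series of measured values in which to rank it.

Compound 3 `CCCCCCCCCCC(CCO)n1cnc2c(N(C)C)ncnc21` is compound 2 with one change: dimethylamino in place of methoxy on an aromatic carbon, (dimethylamino in place of methoxy on an aromatic carbon). Among the measured compounds shown here, no measured pair isolates this swap in this assay, so any forecast is a judgement. Compound 1 also carries dimethylamino and gives the limit > 50000 nM, though its structure differs from compound 2 in more than this one place. A modest move toward weaker inhibition is therefore expected, possibly none beyond the scatter. The estimated change is a 1.5-fold higher number from compound 2 to compound 3 (0.16 log units; within the scatter). For compound 3 the estimate is 12000 nM, with an expected range of 5000 nM to 35000 nM.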

Compound 3, half-maximal inhibitory concentration: 3320 nM
Compound 3: middle estimate off by 3.6-fold (0.56 log units), on the high side, outside the stated range (below it).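

In this assay, with the chain of compound 2 kept, dimethylamino in place of methoxy on the aromatic carbon gives a 2.5-fold lower number from compound 2 to compound 3 (0.40 log units; beyond the scatter), so at this position the swap strengthens inhibition by more than the usual scatter. With dimethylamino held fixed, pentyl in place of hydrogen on the saturated chain carbon gives an at least 15-fold lower number from compound 1 to compound 3 (1.17 log units; beyond the scatter), a large step beside the modest one from the swap, so the chain extension counts for more in this pair of steps. Compound 1 gives a limit and not a number, and the step from it can only be read as a minimum because of this: the limit of > 50000 nM in this assay, at which 1 of the 3 values shown sits.

On these data alone, it remains open whether the swap gives a similar step on the shorter chain of compound 1. Also open, as far as these compounds go, is how a morpholine or a methylamino group at this aromatic carbon, or a chain longer than that of compound 3, would read.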